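Furan-3-yl for furan-2-yl on the shared core

A few compounds are considered here, and "the series" means these few. Any claim that something is new, unique, unknown or untested is made for them only; others in the source may bear on it.

In a functional assay on HT-29 cells (Homo sapiens) for antiproliferative activity (on this read-out lower numbers stand for stronger inhibition of growth and higher numbers for weaker inhibition of growth), compound 2 (`c1ccc(-c2cc(-c3ccco3)cc(-c3ccccn3)n2)nc1`) gives 0.0024 ug/mL and lies within the scatter of compound 1 (`c1ccc(-c2cc(-c3ccsc3)cc(-c3ccccn3)n2)nc1`) at 0.0027 ug/mL on the two numbers available. Compound 3 (`c1ccc(-c2cc(-c3ccoc3)cc(-c3ccccn3)n2)nc1`) has furan-3-yl in place of furan-2-yl on an aromatic carbon opposite the ring nitrogen. For the measured compounds named here, the only measured step (a 1.1-fold lower number from compound 1 to compound 2 (0.05 log units; within the scatter)) put furan-2-yl in place of thiophen-3-yl and stayed within the scatter. No step beyond the scatter is therefore expected in this assay and no direction is favoured for the estimated step (a 1.1-fold higher number from compound 2 to compound 3 (0.03 log units; within the scatter)) here. Compound 3 is estimated at 0.0026 ug/mL with an expected range (0.0011 ug/mL to 0.006 ug/mL).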

Compound 3, concentration for 50% growth inhibition: 0.0026 ug/mL
Estimate against measurement, compound 3: no gap at the digits printed, within the range that was stated.
By their numbers in this assay, from the lowest: compounds 2, 3 and 1 (each within the scatter of the next).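

In this assay, furan-3-yl in place of furan-2-yl on this aromatic carbon, opposite the ring nitrogen, gives a 1.1-fold higher number from compound 2 to compound 3 (0.03 log units; within the scatter) and shows that the point of attachment of the furan leaves the number within the scatter. With the ring attached in the same way, furan-3-yl in place of thiophen-3-yl gives a 1.0-fold lower number from compound 1 to compound 3 (0.02 log units; within the scatter) and also stays within the scatter. No measurement is available to account for this result.

All three groups shown here are five-membered aromatic rings, so it remains open whether an amine, a carboxylic acid or a longer alkyl chain on this carbon would hold the number at this level.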